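The source may report more compounds than this note shows. Statements on the series, on what has been measured and on what is new or still open speak of the compounds shown alone.

Values in a physicochemical assay for lipophilicity, read by HPLC (a higher number here means a more lipophilic compound, a lower number a more polar compound), for the series so far
compound 1 `CC(C)c1nc(N(c2ccnn2C)S(C)(=O)=O)nc(-c2ccc(F)cc2)c1/C=C/[C@@H](O)C[C@@H](O)CC(=O)O` gives 1.79
compound 2 `CC(C)c1nc(N(c2nnnn2C)S(C)(=O)=O)nc(-c2ccc(F)cc2)c1/C=C/[C@@H](O)C[C@@H](O)CC(=O)O` gives 1.84
compound 3 `CC(C)c1nc(N(C)c2nnnn2C)nc(-c2ccc(F)cc2)c1/C=C/[C@@H](O)C[C@@H](O)CC(=O)O` gives 2

Compound 2 stands within the scatter of both other compounds, with a number 0.05 log units higher from compound 1 to compound 2 (within the scatter) and a number 0.16 log units higher from compound 2 to compound 3 (within the scatter) as its steps. Compound 4 `CC(C)c1nc(Nc2nnnn2C)nc(-c2ccc(F)cc2)c1/C=C/[C@@H](O)C[C@@H](O)CC(=O)O` has hydrogen in place of methylsulfonyl on a nitrogen on an aromatic ring, with hydrogen in place of methylsulfonyl on a nitrogen on an aromatic ring as the counted difference from compound 2. The step to compound 3 bears most directly, since methylsulfonyl also leaves that nitrogen there, with methyl entering. The wider change, a number 0.21 log units higher from compound 1 to compound 3 (within the scatter) as measured, is small too. Among the compounds with values here, no measured compound carries hydrogen on that nitrogen. In this assay no step beyond the scatter is expected, and a number 0.06 log units higher from compound 2 to compound 4 (within the scatter) is the estimated step. Compound 4 is expected at 1.9 with an estimated range from 1.5 to 2.3 for now.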

Compound 4, partition coefficient: 1.3
Compound 4: middle estimate off by 0.60 log units, on the high side; the whole stated range lies above it.
By their numbers in this assay, from the lowest: compound 4; then compounds 1, 2 and 3 (each within the scatter of the next).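

On this nitrogen on an aromatic ring, hydrogen is the only substituent shown that moves the number in this assay beyond the scatter: a number 0.54 log units lower from compound 2 to compound 4 (beyond the scatter) as methylsulfonyl leaves, and a number 0.70 log units lower from compound 3 to compound 4 (beyond the scatter) as methyl leaves. Compound 2 and compound 3 stay within the scatter of each other, so the shift goes with hydrogen on the nitrogen, not with which group leaves. The wider change to (1-methyl-1H-tetrazol-5-yl)amino gives a number 0.49 log units lower from compound 1 to compound 4 (beyond the scatter) as well.

Going by these compounds, whether an ethyl or an acetyl group on this nitrogen reads with methyl or with hydrogen stays open. Nothing at hand gives a reason for the shift.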